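Trading a Ring Amine for an Open Chain

The compounds below may be only part of what the source reports. "The series", "measured", "known", "first", "only" and "open" are said of these compounds alone.

In a functional assay on NCI-H460 cells (Homo sapiens) for cytotoxicity, read by MTT assay, with a stated time of 72 h (on this read-out higher numbers stand for weaker inhibition and lower numbers for stronger inhibition), compound 1 (`CCN(CC)Cc1ccc2nc(NC(=O)N/N=C/c3cn(Cc4ccc(C(C)(C)C)cc4)c4ccccc34)sc2c1`) gives 1670 nM and compound 2 (`CC1CCN(Cc2ccc3nc(NC(=O)N/N=C/c4cn(Cc5ccc(Cl)cc5Cl)c5ccccc45)sc3c2)CC1`) gives 1660 nM, so compound 2 stands level with compound 1, within the scatter. Compound 3 (`CCN(CC)Cc1ccc2nc(NC(=O)N/N=C/c3cn(Cc4ccc(Cl)cc4Cl)c4ccccc34)sc2c1`) differs from compound 2 in one place: diethylamino in place of 4-methylpiperidin-1-yl on a saturated chain carbon bound to an aromatic carbon. Diethylamino takes the place of 4-methylpiperidin-1-yl. No clear shift in this assay is expected, in either direction, because compound 1, which also carries diethylamino, gives 1670 nM. The estimated step of a 1.0-fold lower number from compound 2 to compound 3 (0.02 log units; within the scatter) is expected to stay within the scatter. For compound 3 the estimated value is 1600 nM, with an expected range of 750 nM to 3400 nM.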

Compound 3, half-maximal inhibitory concentration: 1080 nM
Beside the measured number, compound 3's estimate is 1.5-fold (0.17 log units) above it; low and high end bracket the measured number.
By their numbers in this assay, from the lowest: compounds 3, 2 and 1 (each within the scatter of the next).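

In this assay, the open chain replaces the ring amine with a 1.5-fold lower number from compound 2 to compound 3 (0.19 log units; within the scatter), so on this saturated chain carbon the read-out does not separate diethylamino from 4-methylpiperidin-1-yl. On a saturated chain carbon bound to an aromatic nitrogen, 2,4-dichlorophenyl in place of 4-(tert-butyl)phenyl likewise gives a 1.5-fold lower number from compound 1 to compound 3 (0.19 log units; within the scatter), with no clear difference. Nothing available explains this result. Still open, from the compounds shown here alone, is how a morpholine ring, a piperazine ring or a carboxylic acid would read at the amine position.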